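The source may report more compounds than this note shows. Statements on the series, on what has been measured and on what is new or still open speak of the compounds shown alone.

Measured so far:
compound 1 `CCN1CCN(CC(=O)NC2(c3ccc(Cl)cc3)C(=O)Nc3cc(Cl)c(Cl)cc32)CC1`; in an in vitro functional assay on CHO-CREluc cells for antagonist activity at growth hormone secretagogue receptor type 1 (Homo sapiens), read by a luciferase reporter, with a stated time of 4 h (a lower number here means a stronger inhibitor, a higher number a weaker inhibitor), compound 1 gives 110 nM.
compound 2 `Cc1cc2c(cc1Cl)NC(=O)C2(NC(=O)CN1CCN(c2ccncc2)CC1)c1ccc(Cl)cc1`; in this assay compound 2 returns only the assay limit of > 10000 nM.

Compound 2 therefore stands at the limit of > 10000 nM in this assay, at which 1 of the 2 values shown sits, with no number behind it. Compound 3 `CCN1CCN(CC(=O)NC2(c3ccc(Cl)cc3)C(=O)Nc3cc(Cl)c(C)cc32)CC1` differs from compound 2 in one place: ethyl in place of pyridin-4-yl on an amine nitrogen in a ring. Among the compounds with values here, no measured pair covers this change directly. Since compound 1 carries the same ethyl group and gives 110 nM, a clear gain in potency is expected, estimated as an at least 33-fold lower number from compound 2 to compound 3 (1.52 log units; beyond the scatter). Compound 3 is accordingly estimated at 300 nM in this assay, with a range of 80 nM to 2000 nM.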

Compound 3, half-maximal inhibitory concentration: 129 nM
Compound 3: the middle estimate sits 2.3-fold (0.37 log units) above what was measured; the range from low to high includes it.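

In this assay, ethyl in place of pyridin-4-yl on the amine nitrogen in a ring gives an at least 77-fold lower number from compound 2 to compound 3 (1.88 log units; beyond the scatter), a direct reading of this position with the rest of the molecule unchanged. Compound 2 stands only at a limit of the assay, so this step has a floor and no exact size: the limit of > 10000 nM in this assay, at which 1 of the 3 values shown sits. Methyl in place of chloro on an aromatic carbon gives a 1.2-fold higher number from compound 1 to compound 3 (0.07 log units; within the scatter), so ethyl goes with similar values alongside either group.

The compounds shown do not tell whether the pyridine nitrogen or the size of the ring separates pyridin-4-yl from ethyl. A phenyl ring on this nitrogen would address that, and a propyl chain would test how far the alkyl group can grow.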